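The source may report more compounds than this note shows. Statements on the series, on what has been measured and on what is new or still open speak of the compounds shown alone.

Measured compounds:
- compound 1 `CCCCCCNC(=O)[C@H]1OC(n2cnc3c(N)ncnc32)[C@H](O)[C@@H]1O`: 19 nM
- compound 2 `CC(=O)NCCNC(=O)[C@H]1OC(n2cnc3c(N)ncnc32)[C@H](O)[C@@H]1O`: 46 nM
- compound 3 `CC1CCCCC1NC(=O)[C@H]1OC(n2cnc3c(N)ncnc32)[C@H](O)[C@@H]1O`: 69.5 nM

All three were tested in an assay on cell membranes for binding affinity to 2-oxoglutarate receptor 1 (Rattus norvegicus), read by radioligand binding; a lower number here means a stronger inhibitor, a higher number a weaker inhibitor. Compound 3 has the highest number of the three, but one of its two gaps is small (a 1.5-fold higher number from compound 2 to compound 3 (0.18 log units; within the scatter)), so those two cannot be ranked against each other; only the other gap is clearly beyond the scatter (a 3.7-fold higher number from compound 1 to compound 3 (0.56 log units; beyond the scatter)). The remaining step, from a chain carrying a butyl to one carrying an acetamido group, is also modest (a 2.4-fold higher number from compound 1 to compound 2 (0.38 log units; beyond the scatter)).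

Compound 4 `Nc1ncnc2c1ncn2C1O[C@H](C(=O)NC2CC3CCC2C3)[C@@H](O)[C@H]1O` differs from compound 3 in one place: a group of 7 heavy atoms (7 carbon; 2 five-membered non-aromatic rings of carbon only) in place of a group of 7 heavy atoms (7 carbon; one six-membered non-aromatic ring of carbon only), on an amide-type nitrogen. The two steps that touch this same amide nitrogen, with a hexyl or a 2-acetamidoethyl group in place of the 2-methylcyclohexyl, both stayed modest, and the group entering here keeps the same count of carbon atoms as the one leaving, with neither donors nor acceptors gained or lost. Within the data shown here, no measured step shows exactly this swap, so the expectation rests on the general modesty of changes at this nitrogen. The step from compound 3 to compound 4 is expected to be a 1.2-fold lower number from compound 3 to compound 4 (0.06 log units; within the scatter), within the scatter in either direction. Compound 4 is therefore estimated at 60 nM in this assay, within a range of 25 nM to 150 nM.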

Compound 4, inhibition constant: 640 nM
The estimate for compound 4 lay 11-fold (1.03 log units) below the measured number; the measured number lies above the stated range.
By their numbers in this assay, from the lowest: compound 1; then compounds 2 and 3 (each within the scatter of the next); then compound 4.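

In this assay, this amide nitrogen proves far less forgiving than the first three compounds suggested: a 9.2-fold higher number from compound 3 to compound 4 (0.96 log units; beyond the scatter) appears when 2-methylcyclohexyl gives way to a group with 2 five-membered non-aromatic rings of carbon only. Both groups have 7 carbon atoms and neither has hydrogen-bond donors or acceptors, so these counts alone do not foretell the outcome at this position; how the same carbon atoms are arranged into rings can matter. The open-chain groups also sit well apart from the new group, with a 14-fold higher number from compound 2 to compound 4 (1.14 log units; beyond the scatter) for the 2-acetamidoethyl compound and a 34-fold higher number from compound 1 to compound 4 (1.53 log units; beyond the scatter) for the hexyl compound, which leaves compound 4 with the highest number of the four.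

Nothing available explains why this ring arrangement gives so much higher a number. A plain cyclohexyl, a cyclopentyl or a benzyl group on the same nitrogen would be needed to tell whether the jump belongs to this particular pair of rings or to ring groups at this nitrogen more broadly.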